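From Fluoro to Iodo: Estimating Compound 4

A few compounds are considered here, and "the series" means these few. Any claim that something is new, unique, unknown or untested is made for them only; others in the source may bear on it.

Measured in a functional assay on U-87MG ATCC cells (Homo sapiens) for cytotoxicity, read by MTT assay, with a stated time of 48 h; a higher number here means a weaker inhibitor, a lower number a stronger inhibitor
- compound 1 `C/C(=N/NC(=S)Nc1ccc(Cl)cc1)c1ccccn1` gives 1.7 nM
- compound 2 `C/C(=N/NC(=S)Nc1ccc([N+](=O)[O-])cc1)c1ccccn1` gives 160 nM
- compound 3 `C/C(=N/NC(=S)Nc1ccc(F)cc1)c1ccccn1` gives 10 nM

Compound 3 sits in the middle of these three numbers. Compound 4 `C/C(=N/NC(=S)Nc1ccc(I)cc1)c1ccccn1` has iodo in place of fluoro on an aromatic carbon. The closest guide is the exchange between two halogens, a 5.9-fold higher number from compound 1 to compound 3 (0.77 log units; beyond the scatter), which was modest. The nitro steps, such as a 16-fold lower number from compound 2 to compound 3 (1.20 log units; beyond the scatter), were large but say less about iodo. For the measured compounds named here, no iodo compound has been measured, so this is a cautious expectation that iodo will behave more like chloro than fluoro. The expected change is a 3.3-fold lower number from compound 3 to compound 4 (0.52 log units; beyond the scatter), a modest shift towards a stronger inhibitor. Compound 4 is estimated at 3 nM, within an expected range of 0.8 nM to 12 nM.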

Compound 4, half-maximal inhibitory concentration: 59 nM
Beside the measured number, compound 4's estimate is 20-fold (1.29 log units) below it; measured number outside the range, above it.
By their numbers in this assay, from the lowest: compound 1; then compound 3; then compound 4; then compound 2.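

Swapping fluoro for iodo gives a 5.9-fold higher number from compound 3 to compound 4 (0.77 log units; beyond the scatter), and swapping chloro for iodo gives a 35-fold higher number from compound 1 to compound 4 (1.54 log units; beyond the scatter), so at this position iodo does not follow chloro, and the three halogens do not rank in periodic-table order. The change from nitro to iodo still gives a 2.7-fold lower number from compound 2 to compound 4 (0.43 log units; beyond the scatter), so the iodo compound stays on the stronger side of the nitro compound. No measurement at hand explains this order. Going by these compounds, whether bromo would sit nearer chloro or iodo remains open, as does how an amine or a methoxy group would behave at this place.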